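A few compounds are considered here, and "the series" means these few. Any claim that something is new, unique, unknown or untested is made for them only; others in the source may bear on it.

Compound 1 `Cc1c(C(=O)N/N=C\c2cccc(F)c2)oc2cccc(O)c12` carries a 3-fluorophenyl on the carbon that bears the double bond to nitrogen. In a functional assay on PC-3 cells (Homo sapiens) for inhibition (on this read-out higher numbers stand for weaker inhibition and lower numbers for stronger inhibition), compound 1 reaches only a limit, >= 40000 nM; this is the limit of >= 40000 nM in this assay, at which 1 of the 2 values shown sits. Compound 2 `Cc1c(C(=O)N/N=C\c2cccc(F)c2O)oc2cccc(O)c12` differs from compound 1 by a hydroxy in place of hydrogen on an aromatic carbon, and in this assay compound 2 gives 12700 nM. That single change brought an at least 3.1-fold lower number from compound 1 to compound 2 (0.49 log units; beyond the scatter). Of the two results shown, compound 2 thus holds the only actual number, the other result being a limit.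

Compound 3 `Cc1c(C(=O)N/N=C\c2cccc(O)c2)oc2cccc(O)c12` has not yet been measured. Relative to compound 2 the change is 3-hydroxyphenyl in place of 3-fluoro-2-hydroxyphenyl on a carbon with a double bond to nitrogen. Within the data shown here, only one measured step bears on this change, namely an at least 3.1-fold lower number from compound 1 to compound 2 (0.49 log units; beyond the scatter), in which a hydroxy on the ring lowered the number. Compound 3 keeps a hydroxy on that ring but loses the fluorine, and the hydroxy now stands as 3-hydroxyphenyl rather than within 3-fluoro-2-hydroxyphenyl. For compound 3 the expected step is therefore a 2.0-fold higher number from compound 2 to compound 3 (0.29 log units; within the scatter), a modest move toward weaker inhibition. Compound 3 is estimated at 25000 nM, with a range from 8000 nM to 80000 nM.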

Compound 3, half-maximal inhibitory concentration: 17600 nM
The estimate for compound 3 lay 1.4-fold (0.15 log units) above the measured number; low and high end bracket the measured number.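

Compound 3 shows that the fluorine is not needed for the gain seen with compound 2: in this assay, 3-hydroxyphenyl in place of 3-fluoro-2-hydroxyphenyl on a carbon with a double bond to nitrogen gives a 1.4-fold higher number from compound 2 to compound 3 (0.14 log units; within the scatter), so the two rings are not told apart on this read-out. Hydroxy in place of fluoro on an aromatic carbon gives an at least 2.2-fold lower number from compound 1 to compound 3 (0.35 log units; beyond the scatter), so both compounds with a hydroxy on this ring now stand apart from the 3-fluorophenyl of compound 1, whether or not a fluorine remains. Both steps from compound 1 can be read only as bounds, since the value of compound 1 is a limit and not a number: the limit of >= 40000 nM in this assay, at which 1 of the 3 values shown sits.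

From the compounds shown here alone, whether the hydroxy itself matters, or a methoxy, an amine or a carboxylic acid on the same ring would serve as well, stays open. The compounds shown vary only the ring on the carbon with a double bond to nitrogen, so what a change in the shared core would do also stays open.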